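Adding chloro to compound 3: a cytotoxicity limit

The source may report more compounds than this note shows. Statements on the series, on what has been measured and on what is new or still open speak of the compounds shown alone.

Measured in an ADME assay on BHK-21 cells (Mesocricetus auratus) for cytotoxicity, read by MTT assay; on this read-out higher numbers stand for lower toxicity in this test and lower numbers for higher toxicity in this test:

Compound 1 `C/C(=N\NC(N)=O)c1ccc2[nH]c(-c3ccc(Cl)cc3)nc2c1`: > 100000 nM (a limit)
Compound 2 `CC(=O)c1ccc2c(c1)nc(-c1ccc(Cl)cc1)n2C1CCCCC1`: > 100000 nM (a limit)
Compound 3 `C/C(=N\NC(N)=O)c1ccc2c(c1)nc(-c1ccccc1)n2C1CCCCC1`: > 100000 nM (a limit)

Going by the values given here, the three compounds give no exact number in this assay, and the series so far stands at the limit of > 100000 nM in this assay, at which 3 of the 3 values shown sit. Compound 3 reaches > 100000 nM, which is a limit and not a measured number. Among the compounds with values here, no pair of measured compounds differing in one place is available, so the data offer no direct guide to the size of a single change.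

Compound 4 `C/C(=N\NC(N)=O)c1ccc2c(c1)nc(-c1ccc(Cl)cc1)n2C1CCCCC1` follows from compound 3 by one change, chloro in place of hydrogen on an aromatic carbon. The phenyl thus becomes a 4-chlorophenyl. That group is already present in compound 1, which gives > 100000 nM, a limit. It is also present in compound 2, which gives > 100000 nM, again a limit. No step beyond the usual scatter is therefore expected, and the estimated change is a number no higher from compound 3 to compound 4 (the limit leaves the size open). The result may well be reported only as a limit. For compound 4 the estimated value is 100000 nM, with an expected range from 50000 nM to 200000 nM.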

Compound 4, half-maximal cytotoxic concentration: > 100000 nM
Compound 4: a limit, no number; the forecaster's own chance of this, stated with the estimate: 80%; the middle value lies on the limit itself.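

Compound 4 gives no number either, only a limit, so the steps to it from compound 1, compound 2 and compound 3 cannot be read: the limit of > 100000 nM in this assay, at which 4 of the 4 values shown sit.

The compounds shown leave open the size of any single change on this read-out, including chloro in place of hydrogen on an aromatic carbon.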